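A few compounds are considered here, and "the series" means these few. Any claim that something is new, unique, unknown or untested is made for them only; others in the source may bear on it.

Compound 1, `CCOC(=O)NC(=O)NC1=CS(=O)(=O)O[C@@]12[C@@H](CO[Si](C)(C)C(C)(C)C)O[C@@H](n1cc(C)c(=O)n(C)c1=O)[C@@H]2O[Si](C)(C)C(C)(C)C`, gives 14000 nM in a functional assay on HEL cells (Homo sapiens); on this read-out lower numbers stand for higher toxicity in this test and higher numbers for lower toxicity in this test.
Compound 2, `COC(=O)C(=O)CNC1=CS(=O)(=O)O[C@@]12[C@@H](CO[Si](C)(C)C(C)(C)C)O[C@@H](n1cc(C)c(=O)n(C)c1=O)[C@@H]2O[Si](C)(C)C(C)(C)C`, reaches only a limit of this assay, > 200000 nM.
Compound 3, `Cc1cn([C@@H]2O[C@H](CO[Si](C)(C)C(C)(C)C)[C@@]3(OS(=O)(=O)C=C3NC(=O)NC(=O)c3ccccc3)[C@H]2O[Si](C)(C)C(C)(C)C)c(=O)n(C)c1=O`, likewise stops at a limit, >= 200000 nM.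

Within the data shown here, compound 1 thus stands as the only compound with a real number; the other two values are limits, marked by the limit of > 200000 nM in this assay, at which 1 of the 3 values shown sits, and (the limit of >= 200000 nM in this assay, at which 1 of the 3 values shown sits). The unmeasured compound 4, `Cc1cn([C@@H]2O[C@H](CO[Si](C)(C)C(C)(C)C)[C@@]3(OS(=O)(=O)C=C3NCC(=O)C(=O)O)[C@H]2O[Si](C)(C)C(C)(C)C)c(=O)n(C)c1=O`, differs from compound 1 by (carboxycarbonyl)methyl in place of (ethoxycarbonyl)carbamoyl on an amine nitrogen. The step that bears most directly on it is an at least 14-fold higher number from compound 1 to compound 2 (1.15 log units; beyond the scatter), since compound 2 carries the same chain as compound 4 with its acid closed as an ester. The step of an at least 14-fold higher number from compound 1 to compound 3 (1.15 log units; beyond the scatter) is also large and in the same direction, so every change tried so far at this amine nitrogen has pushed the number up to the limit. Compound 4 is therefore expected to follow compound 2, with a step of a 14-fold higher number from compound 1 to compound 4 (1.15 log units; beyond the scatter). The estimate for compound 4 is 200000 nM, expected to lie between 60000 nM and 400000 nM, most likely reported again as a limit.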

Compound 4, half-maximal cytotoxic concentration: 146000 nM
Estimate against measurement, compound 4: 1.4-fold (0.14 log units) above; low and high end bracket the measured number.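

In this assay, compound 4 gives a real number for a chain at this amine nitrogen where compound 2 and compound 3 gave only limits, so the change from (ethoxycarbonyl)carbamoyl to (carboxycarbonyl)methyl now has a readable size: a 10-fold higher number from compound 1 to compound 4 (1.02 log units; beyond the scatter). Opening the methyl ester to the acid gives only a floor, an at least 1.3-fold lower number from compound 2 to compound 4 (0.13 log units; that floor lies within the scatter), and that floor lies within the scatter. Replacing benzoylcarbamoyl is no clearer, with an at least 1.3-fold lower number from compound 3 to compound 4 (0.13 log units; that floor lies within the scatter), a floor that also lies within the scatter, and the value of compound 3 is itself a limit: the limit of >= 200000 nM in this assay, at which 1 of the 4 values shown sits.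

Going by these compounds, whether the acid and its methyl ester truly differ stays open, because compound 2 rests on a limit: the limit of > 200000 nM in this assay, at which 1 of the 4 values shown sits. Also open is how a primary amide in place of the acid, or a longer chain at this nitrogen, would read in this assay.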